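Aryl Exchanges in the Series: Outlook for Compound 4

The source may hold more compounds than are shown below. What is called first, only, known or untested is meant among the compounds shown, and "the series" means these compounds.

Compound 1 `COc1cccc(N2CCN(C(=O)C(C)N3C(=O)CCC3=O)CC2)c1`, compound 2 `CC(C(=O)N1CCN(c2ccc(Cl)cc2)CC1)N1C(=O)CCC1=O` and compound 3 `CC(C(=O)N1CCN(c2ccccc2F)CC1)N1C(=O)CCC1=O` share one core and differ only in the aryl group on an amine nitrogen in a ring. In a functional assay on the whole organism (strain Swiss) with Mus musculus as the target, in the maximal electroshock model, with a stated time of 1 h, at a dose of 100 mg/kg by the intraperitoneal route (a lower number here means a weaker effect, a higher number a stronger effect of the compound at the dose given), compound 1 gives 0%, compound 2 gives 0% and compound 3 gives 0%, so compound 3 stands level with both others. The steps of no change at the digits printed from compound 1 to compound 2 (within the scatter), no change at the digits printed from compound 1 to compound 3 (within the scatter) and no change at the digits printed from compound 2 to compound 3 (within the scatter) all lie within the scatter. Compound 4 `Cc1cccc(N2CCN(C(=O)C(C)N3C(=O)CCC3=O)CC2)c1` differs from compound 3 by 3-methylphenyl in place of 2-fluorophenyl on an amine nitrogen in a ring. Three aryl exchanges at the same place moved nothing, so for compound 4 no step beyond the scatter is expected in this assay, the expected step being no change at the digits printed from compound 3 to compound 4 (within the scatter). Compound 4 is estimated at 0%, range 0% to 10%.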

Compound 4, a percentage reported as activity, at one dose (the size of the read-out at that dose, not a potency): 0%
The estimate for compound 4 equals the measured number at the digits printed, within the range that was stated.
By their numbers in this assay, from the lowest: compounds 1, 2, 3 and 4 (each within the scatter of the next).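

In this assay the change to 3-methylphenyl gives no change at the digits printed from compound 3 to compound 4 (within the scatter) and no change at the digits printed from compound 2 to compound 4 (within the scatter). The new point is an exchange within the substituent on the aryl group: methyl in place of methoxy on an aromatic carbon gives no change at the digits printed from compound 1 to compound 4 (within the scatter) and so leaves the read-out as flat as the earlier swaps of the whole aryl group did. No supporting data bear on this result.

Still open, going by these compounds, is whether a carboxylic acid or an amine on the aryl group, or a longer chain in its place, would give a read-out in this assay different from that of compound 4 at 0%.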